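Aryl carbamate in place of the aryloxypropyl ether on compound 3

The source may hold more compounds than are shown below. What is called first, only, known or untested is meant among the compounds shown, and "the series" means these compounds.

Compound 3 `CC(C)=CCC/C(C)=C/CC1Cc2c(OCCCOc3ccc(Cl)cc3)cc(=O)n(CCCO)c2CC1(C)C` stands lowest of the three measured compounds in a functional assay on PANC-1 cells (Homo sapiens) for inhibition, read by MTT assay, with a stated time of 24 h, tested at 10 uM (on this read-out higher numbers stand for more inhibition at the one concentration tested (going by the name of the read-out) and lower numbers for less inhibition), giving 25.2%. Compound 1 `CC(C)=CCC/C(C)=C/CC1Cc2c(O)cc(=O)n(CCCO)c2CC1(C)C` gives 28.7%, a gap of a number 3.5 percentage points lower from compound 1 to compound 3 (within the scatter), while compound 2 `CC(C)=CCC/C(C)=C/CC1Cc2c(OCc3ccccc3)cc(=O)n(CCCO)c2CC1(C)C` gives 46.5%, with a number 21.3 percentage points lower from compound 2 to compound 3 (beyond the scatter). Compound 4 `CC(C)=CCC/C(C)=C/CC1Cc2c(OC(=O)Nc3cccc(F)c3)cc(=O)n(CCCO)c2CC1(C)C` differs from compound 3 by (3-fluorophenyl)carbamoyl in place of 3-(4-chlorophenoxy)propyl on an oxygen on an aromatic ring. The steps bearing on this oxygen are a number 17.8 percentage points higher from compound 1 to compound 2 (beyond the scatter) and a number 21.3 percentage points lower from compound 2 to compound 3 (beyond the scatter): a benzyl group on that oxygen raised the read-out, the 3-(4-chlorophenoxy)propyl group did not. The (3-fluorophenyl)carbamoyl group is again a single-ring substituent on the same oxygen, so a modest upward step in this assay is expected, a number 10.8 percentage points higher from compound 3 to compound 4 (beyond the scatter). Compound 4 is estimated at 36%, between 16% and 56%.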

Compound 4, a percentage reported as inhibition, at one concentration (the size of the read-out at that concentration, not a potency): 52.3%
Estimate against measurement, compound 4: 16.3 percentage points below, within the range that was stated.
By their numbers in this assay, from the lowest: compounds 3 and 1 (each within the scatter of the next); then compounds 2 and 4 (each within the scatter of the next).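

On an oxygen on an aromatic ring in this assay, the (3-fluorophenyl)carbamoyl group gives a number 23.6 percentage points higher from compound 1 to compound 4 (beyond the scatter) and a number 27.1 percentage points higher from compound 3 to compound 4 (beyond the scatter), so a group other than benzyl can also lift the read-out at this position. Against benzyl, it gives a number 5.8 percentage points higher from compound 2 to compound 4 (within the scatter), so these two groups cannot be separated here. No available evidence explains the effect of this change.

As far as these compounds go, the separate contributions of the fluorine and the carbamoyl link remain open. So does the effect of an unsubstituted phenylcarbamoyl group or a dimethylcarbamoyl group on this oxygen.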